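Thallium flux series: methyl removal on the acid-bearing ring

The compounds below may be only part of what the source reports. "The series", "measured", "known", "first", "only" and "open" are said of these compounds alone.

Measured compounds:
compound 1 `COc1ccc(C(=O)O)cc1OCCCCOc1ccc(C(=O)CC2CCCC2)c(O)c1C` gives 91.8%
compound 2 `Cc1c(OCCCCOc2ccc(C(=O)O)cc2F)ccc(C(=O)CC2CCCC2)c1O` gives 83.8%
compound 3 `Cc1ccc(C(=O)O)cc1OCCCCOc1ccc(C(=O)CC2CCCC2)c(O)c1C` gives 67.5%

In an assay on HEK293 cells for positive allosteric modulation of metabotropic glutamate receptor 2 (Rattus norvegicus), read by thallium flux, with a stated time of 2.5 min (a higher number here means a larger maximal response, a lower number a smaller maximal response), compound 3 stands lowest of the three numbers: the step of a number 24.3 percentage points lower from compound 1 to compound 3 (beyond the scatter) and the step of a number 16.3 percentage points lower from compound 2 to compound 3 (beyond the scatter) both lie beyond the scatter, while a number 8 percentage points lower from compound 1 to compound 2 (within the scatter) does not. Compound 4 `Cc1c(OCCCCOc2cccc(C(=O)O)c2)ccc(C(=O)CC2CCCC2)c1O` differs from compound 3 by hydrogen in place of methyl on an aromatic carbon. Going by the values given here, no measured step removes a methyl for hydrogen; the nearest is a number 24.3 percentage points lower from compound 1 to compound 3 (beyond the scatter), where a change at an aromatic carbon of the same ring cost a modest amount. Because a number 24.3 percentage points lower from compound 1 to compound 3 (beyond the scatter) links the methyl-bearing ring of compound 3 to the lowest value, a modest rise is expected on its removal, a number 10.5 percentage points higher from compound 3 to compound 4 (beyond the scatter). Compound 4 is estimated at 78%, within 60% to 96%.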

Compound 4, largest response reached (reported as percent of maximum), in percent of the reference or control that the assay uses: 80.6%
The estimate for compound 4 lay 2.6 percentage points below the measured number; low and high end bracket the measured number.
By their numbers in this assay, from the lowest: compound 3; then compounds 4, 2 and 1 (each within the scatter of the next, the first and the last beyond it).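

In this assay, a number 13.1 percentage points higher from compound 3 to compound 4 (beyond the scatter) ties the low number of compound 3 to the methyl para to the carboxy group, since hydrogen at that carbon restores much of the response. With a number 11.2 percentage points lower from compound 1 to compound 4 (beyond the scatter), the same carbon now reads in order: methoxy, then hydrogen, then methyl, with each gap beyond the scatter. The step of a number 3.2 percentage points lower from compound 2 to compound 4 (within the scatter) does not separate 3-carboxyphenyl from 4-carboxy-2-fluorophenyl.

Nothing here explains this order at the carbon. Going by these compounds, whether an ethoxy or a chlorine at that carbon would follow methoxy or methyl remains open.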